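The source may report more compounds than this note shows. Statements on the series, on what has been measured and on what is new or still open speak of the compounds shown alone.

Measured so far:
- Compound 1 `COc1cc2c(cc1CC=C(C)C)C(=O)C[C@@H](c1ccc(Oc3ccc(F)cc3)cc1)O2`: 19%
- Compound 2 `COc1cc2c(cc1CC=C(C)C)C(=O)C[C@@H](c1ccc(Oc3cccc([N+](=O)[O-])c3)cc1)O2`: 21%

In a functional assay on PC-3 cells (Homo sapiens) for inhibition, read by sulforhodamine B assay, with a stated time of 48 h, tested at 50 uM (on this read-out higher numbers stand for more inhibition of growth at the one concentration tested and lower numbers for less inhibition of growth), compound 2 gives 21%. For the measured compounds named here, only one other number is available for comparison, and it lies within the scatter of compound 2: a number 2 percentage points higher from compound 1 to compound 2 (within the scatter). Both compounds therefore show similar, modest growth inhibition at the single concentration tested.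

The next compound is compound 3 `COc1cc2c(cc1CC=C(C)C)C(=O)C[C@@H](c1ccc(Oc3ccccc3)cc1)O2`, which has not yet been measured. It keeps the shared core and removes the substituent from the outer ring, so 3-nitrophenyl becomes phenyl: hydrogen in place of nitro on an aromatic carbon. In short, hydrogen stands in place of nitro on an aromatic carbon.

Going by the values given here, only one measured step bears on this change, and it also alters only the outer group on the oxygen: a number 2 percentage points higher from compound 1 to compound 2 (within the scatter). That single step shows that exchanging 4-fluorophenyl for 3-nitrophenyl left the number within the scatter. Among the compounds with values here, no compound with the plain phenyl group has been measured, so this is limited evidence, and no step beyond the scatter is expected in this assay.

The expected change is a number 1 percentage points lower from compound 2 to compound 3 (within the scatter).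

For compound 3, the estimated value is 20%, with an expected range from 9% to 32%.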

Compound 3, percent growth inhibition at one concentration: 53%
Estimate against measurement, compound 3: 33 percentage points below; measured number outside the range, above it.
By their numbers in this assay, from the lowest: compounds 1 and 2 (each within the scatter of the next); then compound 3.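

In this assay, taking the nitro group off the outer ring, so that 3-nitrophenoxy becomes phenoxy, gives a number 32 percentage points higher from compound 2 to compound 3 (beyond the scatter), and taking off the fluoro group gives a number 34 percentage points higher from compound 1 to compound 3 (beyond the scatter). The earlier pair showed only that 4-fluorophenyl and 3-nitrophenyl gave numbers within the scatter of each other, which could have meant that this outer ring hardly matters; the plain phenyl group now shows that it does, since it stands well apart from both substituted rings. Nothing available here explains why the unsubstituted ring gives the higher number.

With only two substituents shown, each at a single place on the ring, it remains open whether any added group lowers the number or only these two do, and whether fluoro and nitro would give the same result if their places were exchanged. A methyl group, a methoxy group, an amine or a carboxylic acid on this ring could show whether growth inhibition stays near that of compound 3 or falls back towards that of compound 1 and compound 2.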